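Methoxy to Hydroxy: Expected Effect on Growth Inhibition

The compounds below may be only part of what the source reports. "The series", "measured", "known", "first", "only" and "open" are said of these compounds alone.

Measured in a functional assay on HCT-116 cells (Homo sapiens) for inhibition, read by sulforhodamine B assay, with a stated time of 48 h; a lower number here means a stronger inhibitor of growth, a higher number a weaker inhibitor of growth:
compound 1 `COc1cc(-c2nn(-c3cccc(NC(=O)Nc4cc(C(F)(F)F)cc(C(F)(F)F)c4)c3)cc2-c2ccncc2)ccc1Cl` gives 1760 nM
compound 2 `COc1cc(-c2nn(-c3cccc(NC(=O)Nc4ccc(Cl)c(Cl)c4)c3)cc2-c2ccncc2)ccc1Cl` gives only a limit of the assay, > 50000 nM
compound 3 `O=C(Nc1cccc(-n2cc(-c3ccncc3)c(-c3ccc(Cl)c(O)c3)n2)c1)Nc1ccc(Cl)c(Cl)c1` gives 5730 nM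

Compound 3 arises from compound 2 by hydrogen in place of methyl on an oxygen on an aromatic ring, and the step is an at least 8.7-fold lower number from compound 2 to compound 3 (0.94 log units; beyond the scatter); its size is known only as a lower bound because of the limit of > 50000 nM in this assay, at which 1 of the 3 values shown sits. Compound 1 and compound 2 differ in more than one place, and the difference between the two cores is not broken down here. Compound 4 `O=C(Nc1cccc(-n2cc(-c3ccncc3)c(-c3ccc(Cl)c(O)c3)n2)c1)Nc1cc(C(F)(F)F)cc(C(F)(F)F)c1` stands to compound 1 as compound 3 stands to compound 2, by hydrogen in place of methyl on an oxygen on an aromatic ring, the same change at the same place. For compound 4 the step of a 3.5-fold lower number from compound 1 to compound 4 (0.55 log units; beyond the scatter) is expected, resting on the step of an at least 8.7-fold lower number from compound 2 to compound 3 (0.94 log units; beyond the scatter), though compound 1 already gives 1760 nM, so a smaller gain is estimated. Compound 4 is expected to give about 500 nM, between 150 nM and 1800 nM.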

Compound 4, concentration for total growth inhibition: 1110 nM
For compound 4 the middle estimate is 2.2-fold (0.35 log units) below the measured one, within the range that was stated.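

In this assay, swapping methoxy for hydroxy gives a 1.6-fold lower number from compound 1 to compound 4 (0.20 log units; within the scatter), so on this core the change has no effect that can be told apart from repeat scatter. The same change therefore does not carry over at the same size from one core to the other: the same change on two cores in this assay, an at least 8.7-fold lower number (0.94 log units; beyond the scatter) from compound 2 to compound 3 and a 1.6-fold lower number (0.20 log units; within the scatter) from compound 1 to compound 4, at least 5.5-fold (0.74 log units) apart, beyond the scatter of two such steps

This does not show why the two cores differ, and the larger step is known only as a lower bound: the limit of > 50000 nM in this assay, at which 1 of the 4 values shown sits.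

Going by these compounds alone, with only two pairs, the size of this change on any further core remains open. Also open, going by these compounds, is how an amine or a carboxylic acid in place of the hydroxy would behave on either core.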